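This account rests on a few compounds, and the source may have more. Where it says the series, first, only, none or still open, it means among the compounds named here.

Measured so far:
- compound 1 `O=S(=O)(Nc1ncccn1)c1ccc2c(c1)OCC[C@@H]2c1ccc(C(F)(F)F)cc1-c1ccc(F)nc1`: 408000 nM
- compound 2 `O=S(=O)(Nc1ccncn1)c1ccc2c(c1)OCC[C@@H]2c1ccc(C(F)(F)F)cc1-c1ccc(F)cn1`: 181000 nM

In a physicochemical assay for solubility (a lower number here means a less soluble compound, a higher number a more soluble compound), compound 2 gives 181000 nM, the lower of the two numbers. Among the measured compounds shown here, the only comparison is compound 1 at 408000 nM, and that gap lies beyond the usual scatter.

The next compound to be tested is compound 3 `O=S(=O)(Nc1ncccn1)c1ccc2c(c1)OCC[C@@H]2c1ccc(C(F)(F)F)cc1-c1ccc(F)cn1`. It differs from compound 2 by one exchange, pyrimidin-2-yl in place of pyrimidin-4-yl on a sulfonamide nitrogen. The two have the same atoms, joined differently.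

For the measured compounds named here, no measured pair differs in one place only, so the size of this exchange in this assay has not been seen directly. Going by the values given here, the only guide is that pyrimidin-2-yl also stands in compound 1, which gives 408000 nM. A modest rise is therefore expected, though it may stay within the scatter. The expected change is a 1.4-fold higher number from compound 2 to compound 3 (0.14 log units; within the scatter). For compound 3 the estimated value is 250000 nM, with an expected range from 120000 nM to 500000 nM.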

Compound 3, solubility: 225000 nM
The estimate for compound 3 lay 1.1-fold (0.05 log units) above the measured number; measured number inside the range.
By their numbers in this assay, from the lowest: compounds 2, 3 and 1 (each within the scatter of the next, the first and the last beyond it).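

In this assay, the exchange of pyrimidin-4-yl for pyrimidin-2-yl on a sulfonamide nitrogen can now be read alone: the step is a 1.2-fold higher number from compound 2 to compound 3 (0.09 log units; within the scatter), so at this place the two isomeric rings, with the same atoms joined differently, are not told apart by this read-out. Among the compounds shown here, compound 3 also gives the first reading of the exchange on the aromatic carbon, 5-fluoropyridin-2-yl in place of 6-fluoropyridin-3-yl, with the step of a 1.8-fold lower number from compound 1 to compound 3 (0.26 log units; within the scatter), so this exchange too stays inside the scatter and neither single exchange has a size that can be told from repeat measurements. No measurement is available that would explain either step.

It remains open whether a group on the sulfonamide nitrogen that is not a pyrimidine, such as a thiazole or a plain phenyl ring, would also leave the number in this assay within the scatter of these compounds. On these data alone, it is equally open how the number would respond if the fluorine on the pyridine ring gave way to a methoxy group, a nitrile or an amine.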